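A few compounds are considered here, and "the series" means these few. Any claim that something is new, unique, unknown or untested is made for them only; others in the source may bear on it.

Compound 1, `CC(=O)O[C@@H]1[C@H](OC(C)=O)[C@@H](CI)O[C@H]1n1cnc2c(N)nc(F)nc21`, is the strongest inhibitor of the three measured here: in an ADME assay on L6 cells (Rattus norvegicus) for inhibition, read by resazurin assay, with a stated time of 72 h (a higher number here means a weaker inhibitor, a lower number a stronger inhibitor), compound 1 gives 6300 nM. Compound 2, `CC(=O)O[C@@H]1[C@H](OC(C)=O)[C@@H](CI)O[C@H]1n1cnc2c(N)nc(Cl)nc21`, differs from it by chloro in place of fluoro on an aromatic carbon, and in this assay compound 2 gives 86000 nM, so that the change gave a 14-fold higher number from compound 1 to compound 2 (1.14 log units; beyond the scatter). Compound 3, `CC(=O)NC[C@H]1O[C@@H](n2cnc3c(N)nc(F)nc32)[C@H](O)[C@@H]1O`, has a different core; how its core differs from that of compound 1 is not broken down here. In this assay compound 3 gives 182000 nM, the highest number of the three. Compound 4, `CC(=O)NC[C@H]1O[C@@H](n2cnc3c(N)nc(Cl)nc32)[C@H](O)[C@@H]1O`, carries the same change relative to compound 3, namely (chloro in place of fluoro on an aromatic carbon), at the same place. Because compound 1 to compound 2 showed a 14-fold higher number from compound 1 to compound 2 (1.14 log units; beyond the scatter), the step from compound 3 to compound 4 is expected to be a 2.5-fold higher number from compound 3 to compound 4 (0.39 log units; beyond the scatter), though a smaller rise is plausible since compound 3 already lies so high. Compound 4 is therefore estimated at 450000 nM, within 150000 nM to 1500000 nM.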

Compound 4, half-maximal inhibitory concentration: 189000 nM
For compound 4 the middle estimate is 2.4-fold (0.38 log units) above the measured one; low and high end bracket the measured number.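

In this assay, chloro in place of fluoro on an aromatic carbon gave a 1.0-fold higher number from compound 3 to compound 4 (0.02 log units; within the scatter) and so had no effect that can be told from the scatter on the core of compound 3, unlike on the core of compound 1. The change therefore did not carry over in size from one core to the other: the same change on two cores in this assay, a 14-fold higher number (1.14 log units; beyond the scatter) from compound 1 to compound 2 and a 1.0-fold higher number (0.02 log units; within the scatter) from compound 3 to compound 4, 13-fold (1.12 log units) apart, beyond the scatter of two such steps. Among the compounds shown here, with only two pairs, this does not show which difference between the cores matters, nor how the change would behave on a further core.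

The compounds shown leave open how a bromo group or an amine would compare with fluoro and chloro at this place, between two ring nitrogen atoms, on either core.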